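A few compounds are considered here, and "the series" means these few. Any claim that something is new, unique, unknown or untested is made for them only; others in the source may bear on it.

Measured so far:
- compound 1 `Cc1nnc(-c2nn(-c3ccccc3)c(-c3ccccc3)c2C#N)c2cn(-c3ccccc3)nc12`: > 100000 nM
- compound 2 `N#Cc1c(-c2nnc(O)c3nn(-c4ccccc4)cc23)nn(-c2ccccc2)c1-c1ccccc1`: 61800 nM
- compound 3 `N#Cc1c(-c2nnc(O)c3nn(-c4ccc(Cl)cc4)cc23)nn(-c2ccccc2)c1-c1ccccc1`: 32800 nM

In a functional assay on OVCAR-5 cells (Homo sapiens) for inhibition, read by sulforhodamine B assay, with a stated time of 48 h (on this read-out lower numbers stand for stronger inhibition of growth and higher numbers for weaker inhibition of growth), compound 1 gives > 100000 nM, which is a limit and not a number. Compound 2 gives 61800 nM and compound 3 gives 32800 nM. Among the compounds with values here, these are the only two true numbers, and they lie within the scatter of each other.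

Compound 4 `N#Cc1c(-c2nnc(-c3ccccc3)c3nn(-c4ccccc4)cc23)nn(-c2ccccc2)c1-c1ccccc1` differs from compound 2 by phenyl in place of hydroxy on an aromatic carbon. Within the data shown here, two measured steps bear on this. The change at the same carbon, hydroxy in place of methyl, is an at least 1.6-fold lower number from compound 1 to compound 2 (0.20 log units; that floor lies within the scatter). The change at another place, chloro in place of hydrogen, is a 1.9-fold lower number from compound 2 to compound 3 (0.28 log units; within the scatter). Neither goes beyond the scatter, so no step beyond the scatter is expected in this assay, and a result at the limit remains possible. The expected change is a 1.1-fold higher number from compound 2 to compound 4 (0.05 log units; within the scatter). The estimated value for compound 4 is 70000 nM, with an expected range of 30000 nM to 150000 nM.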

Compound 4, concentration for 50% growth inhibition: > 100000 nM
Compound 4 was reported as a limit; the forecaster's own chance of this, stated with the estimate: 35%; at least 1.4-fold (0.15 log units) between middle value and limit.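

In this assay, as far as these compounds go, phenyl in place of hydroxy on this aromatic carbon gives an at least 1.6-fold higher number from compound 2 to compound 4 (0.20 log units; that floor lies within the scatter), so the true size of the change is unknown and may be larger than that floor. Compound 4, like compound 1, is reported as a limit and not a number, so among the three groups tried at this carbon only hydroxy gives a true number, and the read-out runs out for the other two: the limit of > 100000 nM in this assay, at which 2 of the 4 values shown sit. The step between compound 1 and compound 4 cannot be read.

From the compounds shown here alone, whether hydroxy is specifically required stays open: an amine or a methoxy group at this carbon would test whether another small group also gives a true number. Whether any group here can bring the number well below that of compound 2 also stays unanswered.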